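The source may hold more compounds than are shown below. What is called first, only, known or untested is meant among the compounds shown, and "the series" means these compounds.

Among the compounds with values here, in an ADME assay on microsomes from liver (Rattus norvegicus) for metabolic stability, read by LC-MS, using NADPH, tested at 3 uM (on this read-out higher numbers stand for a longer-lived compound and lower numbers for a shorter-lived compound), compound 1 (`Cc1ccc2c(C(c3cccs3)C(C#N)C#N)c(-c3ccccc3)[nH]c2c1`) gives 0.0817 h, the lowest of the three numbers measured so far. Compound 3 (`OC(C(c1ccccc1)c1c(-c2ccccc2)[nH]c2ccccc12)C(F)(F)F`) gives 0.303 h and compound 2 (`O=C(C(c1ccccc1)c1c(-c2ccccc2)[nH]c2ccccc12)C(F)(F)F`) gives 0.69 h, both clearly higher. Still unmeasured is compound 4 (`Cc1ccc2c(C(CC(F)(F)F)c3cccs3)c(-c3ccccc3)[nH]c2c1`), which keeps the core of compound 1 and changes one group: 2,2,2-trifluoroethyl in place of dicyanomethyl on a saturated chain carbon bound to two aromatic carbons. In short, 2,2,2-trifluoroethyl stands in place of dicyanomethyl on a saturated chain carbon bound to two aromatic carbons.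

Within the data shown here, no measured step makes this exact swap. Among the measured compounds shown here, the only step at that carbon is a 2.3-fold lower number from compound 2 to compound 3 (0.36 log units; beyond the scatter), a modest move that exchanges one fluorinated group for another, and it shows that a change there can shift the number beyond the usual scatter. The fluorinated compounds offer a further hint, as compound 3 at 0.303 h and compound 2 at 0.69 h both stand above compound 1. However, they also differ from compound 1 elsewhere in the structure, so this hint is weak. A modest rise, similar in size to the measured step, is therefore expected, and the expected step is a 2.2-fold higher number from compound 1 to compound 4 (0.34 log units; beyond the scatter). Compound 4 is estimated at 0.18 h, with an expected range from 0.07 h to 0.45 h.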

Compound 4, half-life: 0.292 h
For compound 4 the middle estimate is 1.6-fold (0.21 log units) below the measured one; the measured number falls inside the stated range.
By their numbers in this assay, from the lowest: compound 1; then compounds 4 and 3 (each within the scatter of the next); then compound 2.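

In this assay, within the data shown here, the swap on a saturated chain carbon bound to two aromatic carbons gives a 3.6-fold higher number from compound 1 to compound 4 (0.55 log units; beyond the scatter), which is the first measured change at this carbon that carries the core of compound 1. Among these compounds, until now the only step there was a 2.3-fold lower number from compound 2 to compound 3 (0.36 log units; beyond the scatter), in a different setting and in the opposite direction, so a change of group at this carbon can now be seen to move the half-life beyond the scatter either way. The two groups share the same count of 5 heavy atoms, while the 2 hydrogen-bond acceptors and 2 triple bonds of dicyanomethyl are gone, so the rise comes without any change in heavy-atom count, and no measurement is at hand to explain it.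

On these data alone, it remains open whether the rise goes with the loss of the nitriles or with the arrival of the fluorines, and a plain ethyl chain or a cyanomethyl group on this carbon would help to separate the two. As far as these compounds go, it also remains open whether the same swap would give a similar step on the core of compound 2.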